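Changing the aryl amine on a shared core

This account rests on a few compounds, and the source may have more. Where it says the series, first, only, none or still open, it means among the compounds named here.

Compound 3 `Cc1ccccc1Nc1nc(SCc2ccc(C(F)(F)F)cc2)nc2ccccc12` gives 36900 nM in a functional assay on PC-3 cells (Homo sapiens) for cytotoxicity, read by MTT assay, with a stated time of 72 h (on this read-out lower numbers stand for stronger inhibition and higher numbers for weaker inhibition), the highest number of the three, though all three lie within the scatter of one another: compound 2 `FC(F)(F)c1ccc(CSc2nc(Nc3ccccc3C(F)(F)F)c3ccccc3n2)cc1` gives 34800 nM and compound 1 `FC(F)(F)c1ccc(CSc2nc(N3CCCCC3)c3ccccc3n2)cc1` gives 25500 nM (a 1.4-fold higher number from compound 1 to compound 2 (0.14 log units; within the scatter); a 1.4-fold higher number from compound 1 to compound 3 (0.16 log units; within the scatter); a 1.1-fold higher number from compound 2 to compound 3 (0.03 log units; within the scatter)). Compound 4 `Fc1ccc(Nc2nc(SCc3ccc(C(F)(F)F)cc3)nc3ccccc23)cc1Cl` differs from compound 3 in one place: 3-chloro-4-fluorophenyl in place of 2-methylphenyl on a nitrogen on an aromatic ring. Among the measured compounds shown here, no measured step replaces one aryl group by another on that nitrogen; the nearest guide is a 1.1-fold higher number from compound 2 to compound 3 (0.03 log units; within the scatter), where methyl in place of trifluoromethyl on an aromatic carbon moved the number only within the scatter. The step to compound 4 is therefore expected to be small, a 1.2-fold lower number from compound 3 to compound 4 (0.09 log units; within the scatter), with no clear direction. Compound 4 is estimated at 30000 nM, between 10000 nM and 90000 nM.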

Compound 4, half-maximal inhibitory concentration: 18600 nM
Compound 4: the middle estimate sits 1.6-fold (0.21 log units) above what was measured; the range from low to high includes it.
By their numbers in this assay, from the lowest: compounds 4, 1, 2 and 3 (each within the scatter of the next).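

The first replacement of one aryl group by another on this nitrogen, 3-chloro-4-fluorophenyl for 2-methylphenyl, stays within the scatter (a 2.0-fold lower number from compound 3 to compound 4 (0.30 log units; within the scatter)), and so does the replacement of 2-(trifluoromethyl)phenyl (a 1.9-fold lower number from compound 2 to compound 4 (0.27 log units; within the scatter)). The step from the piperidin-1-yl compound also stays within it (a 1.4-fold lower number from compound 1 to compound 4 (0.14 log units; within the scatter)), so in this assay none of the four groups at this position separates from the others. No measurement offers an explanation for these numbers. On these data alone, whether a carboxylic acid or a morpholine at this position would move the number beyond the scatter remains open.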